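Thiophene regiochemistry on the anilinopyrimidine core

The source may report more compounds than this note shows. Statements on the series, on what has been measured and on what is new or still open speak of the compounds shown alone.

Measured compounds:
compound 1 `Cc1cccc(Nc2nccc(-c3ccsc3)n2)c1` gives 3800 nM in a functional assay for inhibition, with Homo sapiens as the target; on this read-out lower numbers stand for stronger inhibition and higher numbers for weaker inhibition
compound 2 `Cc1cccc(Nc2nccc(-c3cccs3)n2)c1` gives 300 nM in this assay
compound 3 `COc1cccc(Nc2nccc(-c3cccs3)n2)c1` gives 900 nM in this assay

Two changes are covered. The first, (thiophen-3-yl in place of thiophen-2-yl on an aromatic carbon), has been measured once and gives a 13-fold higher number from compound 2 to compound 1 (1.10 log units; beyond the scatter). The second, (methoxy in place of methyl on an aromatic carbon), gives a 3.0-fold higher number from compound 2 to compound 3 (0.48 log units; beyond the scatter); this is also how the core of compound 3 differs from the core of compound 2.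

Compound 4 `COc1cccc(Nc2nccc(-c3ccsc3)n2)c1` is still to be measured in this assay. It carries the change (thiophen-3-yl in place of thiophen-2-yl on an aromatic carbon). This is the same kind of change as that from compound 2 to compound 1, not the same: the place is meta to a group of 9 heavy atoms in compound 3, and meta to a group of 8 heavy atoms in compound 2. For the measured compounds named here, the step is expected to be a 13-fold higher number from compound 3 to compound 4 (1.12 log units; beyond the scatter), of about the size seen for a 13-fold higher number from compound 2 to compound 1 (1.10 log units; beyond the scatter), because compound 3 gives 900 nM as the only anchor and no second example of the change on this core exists. Compound 4 is estimated at 12000 nM, between 4000 nM and 35000 nM.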

Compound 4, half-maximal inhibitory concentration: 1800 nM
For compound 4 the middle estimate is 6.7-fold (0.82 log units) above the measured one, outside the stated range (below it).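

In this assay, thiophen-3-yl in place of thiophen-2-yl gives a 2.0-fold higher number from compound 3 to compound 4 (0.30 log units; within the scatter), so the large step seen with the methyl group does not carry over to the core of compound 3 at the same size: the same change on two cores in this assay, a 13-fold higher number (1.10 log units; beyond the scatter) from compound 2 to compound 1 and a 2.0-fold higher number (0.30 log units; within the scatter) from compound 3 to compound 4, 6.3-fold (0.80 log units) apart, beyond the scatter of two such steps

The same four compounds read the other way show that methoxy in place of methyl gives a 2.1-fold lower number from compound 1 to compound 4 (0.32 log units; beyond the scatter), opposite in direction to the step between the two thiophen-2-yl compounds: the same change on two cores in this assay, a 3.0-fold higher number (0.48 log units; beyond the scatter) from compound 2 to compound 3 and a 2.1-fold lower number (0.32 log units; beyond the scatter) from compound 1 to compound 4, 6.3-fold (0.80 log units) apart, beyond the scatter of two such steps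

For the compounds shown here, the two changes therefore do not add independently in this set, but with only one pair on each core this shows that the thiophene step varies with the other group, not what sets its size or how it would behave on any further core.

From the compounds shown here alone, it remains open whether the thiophene step stays small or grows again with other groups in place of the methyl or methoxy, such as an amine, a carboxylic acid or a longer alkoxy chain. Each step also rests on a single pair of compounds, so a wider set of such pairs would be needed before any rule for the series could be stated.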